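The source may hold more compounds than are shown below. What is called first, only, known or untested is meant among the compounds shown, and "the series" means these compounds.

In a functional assay on MCF7 cells (Homo sapiens) for inhibition, in the absence of a further agent (on this read-out lower numbers stand for stronger inhibition and higher numbers for weaker inhibition), compound 1 `COc1ccc(N)c2c(=O)cc(-c3ccc(N)cc3)oc12` gives 21000 nM; 19000 nM (2 entries), so it inhibits MCF7 cells only weakly. Compound 2 `Nc1ccc(-c2cc(=O)c3c(N)ccc(F)c3o2)cc1` stands far stronger on these numbers, at 6.9 nM. That is its one numerical result in this assay, as a further entry for compound 2 gives no single number, so its position rests on a single measurement.

Compound 3 `Nc1ccc(-c2cc(=O)c3c(N)c(F)cc(F)c3o2)cc1` is built from compound 2 by one small edit, fluoro in place of hydrogen on an aromatic carbon, at a place ortho to the amino group and meta to the fluoro group already on that ring. Within the data shown here, no pair of measured compounds shows what such a swap does in this assay, so the expectation has little to rest on and stays modest. The estimated change, a 1.4-fold lower number from compound 2 to compound 3 (0.14 log units; within the scatter), is small and leans slightly towards stronger inhibition, and it may not exceed the usual scatter. For compound 3 the expected value is 5 nM, with an estimated range from 1.5 nM to 20 nM.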

Compound 3, half-maximal inhibitory concentration: 6 nM
Compound 3: the middle estimate sits 1.2-fold (0.08 log units) below what was measured, within the range that was stated.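

Among these compounds, the swap of hydrogen for fluoro at this place, ortho to an amino group and meta to a fluoro group, gives a 1.2-fold lower number from compound 2 to compound 3 (0.06 log units; within the scatter) in this assay, the first step between two measured compounds that differ in one place. A step of this size gives no ground for ranking the two compounds, so at this one position the added fluoro leaves the inhibition of MCF7 cells indistinguishable from that of the parent compound. In other words, this aromatic carbon can carry a fluoro in place of hydrogen without a change beyond the scatter, but the data shown offer no reason for that outcome.

A single swap cannot show whether a larger or different group at this place, such as chloro, methyl or hydroxy, would also leave the number within the scatter, or would move it clearly in either direction. It also leaves open whether fluoro in place of hydrogen would act the same way on other carbons of the ring, and each of compound 2 and compound 3 has only one numerical result behind it.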